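Toward a Phenoxymethyl Analogue of Compound 3

The source may hold more compounds than are shown below. What is called first, only, known or untested is meant among the compounds shown, and "the series" means these compounds.

Values measured so far in a functional assay on a cell-free system (plasma, Homo sapiens) for inhibition, with Plasma (Rattus norvegicus) as the target (a higher number here means a weaker inhibitor, a lower number a stronger inhibitor), are these:
Compound 1 `O=c1cc(N2CCNCC2)oc2ccccc12` gives 240000 nM
Compound 2 `O=c1cc(N2CCNCC2)c2cc(OCc3cccnc3)ccc2o1` gives 36000 nM
Compound 3 `COc1c(C)cnc(COc2ccc3c(N4CCNCC4)cc(=O)oc3c2C)c1C` gives 5800 nM

Among these three, compound 3 has the lowest number and is the strongest inhibitor, with both other compounds higher by steps beyond the scatter. Compound 4 `Cc1c(OCCOc2ccccc2)ccc2c(N3CCNCC3)cc(=O)oc12` is the next to be tested. It carries phenoxymethyl in place of 4-methoxy-3,5-dimethylpyridin-2-yl on a saturated chain carbon bound to an oxygen on an aromatic ring, a change that amounts to phenoxymethyl in place of 4-methoxy-3,5-dimethylpyridin-2-yl on a saturated chain carbon bound to an oxygen on an aromatic ring in all.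

Among the measured compounds shown here, no two measured compounds differ in one place only, so the size of this step cannot be read from a measured pair. For the measured compounds named here, compound 2 at 36000 nM shows only that a different side group can leave the number well above that of compound 3. A moderate rise toward weaker inhibition is therefore expected in this assay as the estimated 2.6-fold higher number from compound 3 to compound 4 (0.41 log units; beyond the scatter) for this change. The estimate for compound 4 is 15000 nM with an expected range from 4500 nM to 50000 nM in this measurement.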

Compound 4, half-maximal inhibitory concentration: 14300 nM
Compound 4: the middle estimate sits 1.0-fold (0.02 log units) above what was measured, within the range that was stated.
By their numbers in this assay, from the lowest: compound 3; then compound 4; then compound 2; then compound 1.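

In this assay, among the compounds shown here, replacing 4-methoxy-3,5-dimethylpyridin-2-yl with phenoxymethyl on a saturated chain carbon bound to an oxygen on an aromatic ring gives the first one-place step, a 2.5-fold higher number from compound 3 to compound 4 (0.39 log units; beyond the scatter), which is modest but beyond the scatter. This position therefore accepts an aromatic ring of carbon only in place of one with a hetero atom, at a modest cost to inhibition. Nothing measured here connects this step to a property of either group.

The ring and the oxygen of phenoxymethyl enter together, so the compounds shown leave open which of them accounts for the step. Also open, as far as these compounds go, is how an amine, a carboxylic acid or a longer chain in place of phenoxymethyl would stand in this assay.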